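The compounds below may be only part of what the source reports. "The series", "measured", "known", "first", "only" and "open" are said of these compounds alone.

Measured so far:
- compound 1, `COc1cc2oc(-c3cccc(NC(=O)c4ccc(Br)cc4)c3)cc(=O)c2c(OC)c1OC`: 50.8%
- compound 2, `COc1cc2oc(-c3cccc(C(=O)Nc4ccc(C)cc4)c3)cc(=O)c2c(OC)c1OC`: 92.9%

In a functional assay on SK-MEL-28 cells (Homo sapiens) for inhibition, read by sulforhodamine B assay, tested at 10 uM (a lower number here means less inhibition, a higher number more inhibition at the concentration tested (going by the name of the read-out)), compound 2 stands highest of the two numbers; compound 1 is nearest, and the step of a number 42.1 percentage points higher from compound 1 to compound 2 (beyond the scatter) lies beyond the scatter. Compound 3, `COc1cc2oc(-c3cccc(C(=O)Nc4ccc(Cl)cc4)c3)cc(=O)c2c(OC)c1OC`, is not yet measured in this assay. The change is chloro in place of methyl on an aromatic carbon. For the measured compounds named here, no measured step shows this exchange in isolation; the only measured step, a number 42.1 percentage points higher from compound 1 to compound 2 (beyond the scatter), alters the amide together with its para substituent and so bears only loosely on it. Compound 3 is therefore expected to stay near compound 2, with the step of a number 4.9 percentage points lower from compound 2 to compound 3 (within the scatter) within the scatter. The estimate for compound 3 is 88%, range 70% to 98%.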

Compound 3, a percentage reported as inhibition, at one concentration (the size of the read-out at that concentration, not a potency): 107%
Estimate against measurement, compound 3: 19 percentage points below; measured number above the stated range.
By their numbers in this assay, from the lowest: compound 1; then compound 2; then compound 3.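

In this assay, for the compounds shown here, chloro in place of methyl on the aromatic carbon para to a large group gives a number 14.1 percentage points higher from compound 2 to compound 3 (beyond the scatter) as the first reading of this exchange alone, so the number at this position depends on what the carbon carries. The wider change to (4-chlorophenyl)carbamoyl gives a number 56.2 percentage points higher from compound 1 to compound 3 (beyond the scatter) and extends the gap already seen with the methyl member. No measurement on hand explains either step.

From the compounds shown here alone, whether fluoro, methoxy or an amine on this carbon would read higher or lower stays open. Also open, going by these compounds, is how much of the gap to compound 1 belongs to the amide and how much to the halogen.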